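Methoxy for Nitro on the Benzyl Ether of Compound 3

This account rests on a few compounds, and the source may have more. Where it says the series, first, only, none or still open, it means among the compounds named here.

Within the data shown here, in an assay on CHO cells for displacement of a labelled ligand from Alpha-1A adrenergic receptor (Homo sapiens) (on this read-out lower numbers stand for stronger inhibition and higher numbers for weaker inhibition), compound 3 `COc1cccc(OC)c1OCCNCCOc1ccccc1OCc1cccc([N+](=O)[O-])c1` gives 0.316 nM, the second highest of the three numbers so far. Compound 2 `COc1cccc(OC)c1OCCNCCOc1ccccc1OCc1ccc(Cl)cc1` gives 0.251 nM, and a 1.3-fold higher number from compound 2 to compound 3 (0.10 log units; within the scatter). Compound 1 `COc1cccc(OC)c1OCCNCCOc1ccccc1OCc1ccccc1Cl` gives 1.41 nM, and a 4.5-fold lower number from compound 1 to compound 3 (0.65 log units; beyond the scatter), while a 5.6-fold lower number from compound 1 to compound 2 (0.75 log units; beyond the scatter). Compound 4 `COc1cccc(COc2ccccc2OCCNCCOc2c(OC)cccc2OC)c1` differs from compound 3 by methoxy in place of nitro on an aromatic carbon. Among the measured compounds shown here, no measured step exchanges nitro for methoxy, so only indirect guidance exists: the two benzyl groups of compound 2 and compound 3, bearing different substituents, sit within the scatter of each other, and only compound 1 stands apart. The expected step is therefore small, a 1.6-fold higher number from compound 3 to compound 4 (0.20 log units; within the scatter), with no clear direction. Compound 4 is estimated at 0.5 nM, in a range from 0.15 nM to 1.6 nM.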

Compound 4, inhibition constant: 2 nM
Compound 4: middle estimate off by 4.0-fold (0.60 log units), on the low side, outside the stated range (above it).
By their numbers in this assay, from the lowest: compounds 2 and 3 (each within the scatter of the next); then compounds 1 and 4 (each within the scatter of the next).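

In this assay methoxy in place of nitro gives a 6.3-fold higher number from compound 3 to compound 4 (0.80 log units; beyond the scatter) and so, on this one aromatic carbon, the choice of group alone moves the number beyond the scatter. Against the 4-chlorophenyl group, the 3-methoxyphenyl group gives an 8.0-fold higher number from compound 2 to compound 4 (0.90 log units; beyond the scatter) while against the 2-chlorophenyl group it gives a 1.4-fold higher number from compound 1 to compound 4 (0.15 log units; within the scatter) and so compound 1 no longer stands apart. No evidence at hand accounts for the nitro to methoxy step.

The compounds shown leave open whether a nitrile, an amine or a hydroxyl on this aromatic carbon would fall with nitro or with methoxy.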